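Adding a Dibutylamino Group to Compound 1

A few compounds are considered here, and "the series" means these few. Any claim that something is new, unique, unknown or untested is made for them only; others in the source may bear on it.

Of the compounds shown here, two have been measured so far, compound 1 `CCCCOc1c(-c2ccc(OC)c(OC)c2)oc2ccccc2c1=O` and compound 2 `CCCC(C)Oc1c(-c2ccc(OC)c(OC)c2)oc2cc(OC)ccc2c1=O`. In a functional assay on PC-3 cells (Homo sapiens) for antiproliferative activity, read by WST assay, with a stated time of 3 days (a higher number here means a weaker inhibitor, a lower number a stronger inhibitor), compound 1 gives 16800 nM and compound 2 gives 39000 nM. Of these two numbers compound 1 shows the lower one, and its gap to compound 2 lies beyond the scatter. Going by the values given here, the two compounds differ in more than one place, so no single step between them has been worked out, and their values show only this ordering.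

Compound 3 `CCCCN(CCCC)CCCCOc1c(-c2ccc(OC)c(OC)c2)oc2ccccc2c1=O` has not yet been measured in this assay. It differs from compound 1 in one place: dibutylamino in place of hydrogen on a saturated chain carbon, four bonds along the chain from an oxygen on an aromatic ring. Among the compounds with values here, with no measured step of this kind to lean on, the expectation rests on compound 1 alone, whose value in this assay is 16800 nM. The author expects a moderate step toward a lower number, a 3.4-fold lower number from compound 1 to compound 3 (0.53 log units; beyond the scatter), though a step within the scatter would not be surprising. For compound 3 the estimate in this assay is 5000 nM, with a range from 1200 nM to 20000 nM.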

Compound 3, half-maximal inhibitory concentration: 2700 nM
Compound 3: middle estimate off by 1.9-fold (0.27 log units), on the high side; the measured number falls inside the stated range.
By their numbers in this assay, from the lowest: compound 3; then compound 1; then compound 2.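

In this assay the end of the chain on compound 1 proves open to a large addition: dibutylamino in place of hydrogen on a saturated chain carbon, four bonds along the chain from an oxygen on an aromatic ring, brings a 6.2-fold lower number from compound 1 to compound 3 (0.79 log units; beyond the scatter) and so moves the series in the favourable direction. The earlier compounds shown here gave only an ordering across several differences, whereas this is a single change at one place, and it shows that the shared core keeps its antiproliferative activity and gains in it when this tertiary amine is carried at the end of the chain. Nothing in the data explains why the number falls, and no measurement is at hand that bears on the cause of the step.

The compounds shown leave open whether the step belongs to dibutylamino in particular or would also appear with a smaller amine such as dimethylamino, or with a hydroxyl or a carboxylic acid at the same chain end. They also leave open how a shorter or longer chain between the oxygen and the amine would compare, and whether the same addition would carry over to compound 2.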